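The compounds below may be only part of what the source reports. "The series", "measured", "known", "first", "only" and "open" are said of these compounds alone.

Measured so far in an assay on isolated protein for inhibition of Alpha glucosidase (Homo sapiens), with stated times of 5 min and 15 min, tested at 50 uM; on this read-out lower numbers stand for less inhibition and higher numbers for more inhibition at the one concentration tested (going by the name of the read-out):
- compound 1 `O=C1/C(=C/c2ccccc2)CCC/C1=C\c1ccc(Cl)cc1`: 27.6%
- compound 2 `O=C1/C(=C/c2ccccc2)CCC/C1=C\c1ccccc1F`: 43%

Compound 2 stands highest of the two numbers in this assay; its nearest neighbour is compound 1, and the step of a number 15.4 percentage points higher from compound 1 to compound 2 (beyond the scatter) is beyond the scatter, though modest in size.

Compound 3 `O=C1/C(=C/c2ccccc2)CCC/C1=C\c1cccc(F)c1` is not yet measured. Against compound 2 the change is 3-fluorophenyl in place of 2-fluorophenyl on a double-bonded chain carbon bound to a double-bonded ring carbon; both compounds hold the same atoms and differ only in how they are joined.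

Among the measured compounds shown here, only one measured step exists, a number 15.4 percentage points higher from compound 1 to compound 2 (beyond the scatter), and it changes more than the fluorine alone: a chlorine leaves and a fluorine enters, at a different ring carbon. It therefore bears on the present change only loosely. For the measured compounds named here, no measured pair isolates a move of a fluorine from one ring carbon to another, so nothing fixes either the direction or the size of the coming step. The fair expectation is a step of no more than the scatter, with a slight lean downward toward the level of compound 1.

Compound 3 is expected to give about 38% in this assay, with a range of 22% to 54%.

The expected step is a number 5 percentage points lower from compound 2 to compound 3 (within the scatter), within the usual scatter.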

Compound 3, a percentage reported as inhibition, at one concentration (the size of the read-out at that concentration, not a potency): 39.8%
The estimate for compound 3 lay 1.8 percentage points below the measured number; the range from low to high includes it.
By their numbers in this assay, from the lowest: compound 1; then compounds 3 and 2 (each within the scatter of the next).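

In this assay, among the compounds shown here, 3-fluorophenyl in place of 2-fluorophenyl on a double-bonded chain carbon bound to a double-bonded ring carbon gives a number 3.2 percentage points lower from compound 2 to compound 3 (within the scatter) and is the first change that moves only the fluorine, with no difference that can be read. The step of a number 12.2 percentage points higher from compound 1 to compound 3 (beyond the scatter) stands alongside a number 15.4 percentage points higher from compound 1 to compound 2 (beyond the scatter), so the gap from the 4-chlorophenyl compound no longer rests on a single fluorophenyl compound, and compound 2 and compound 3 sit together at one level. No measurement in hand gives a reason for these numbers.

Each step away from compound 1 still changes the halogen and its ring carbon together, so the gap cannot yet be assigned to either one, and 4-fluorophenyl at this place would separate the two. Going by these compounds, it also remains open whether 2-chlorophenyl or 3-chlorophenyl would fall with the fluorophenyl compounds or with compound 1, and whether a group without halogen, such as 4-methoxyphenyl, would reach the same level in this assay at all.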